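The source may report more compounds than this note shows. Statements on the series, on what has been measured and on what is new or still open speak of the compounds shown alone.

Series notes, tolerance on Vero cells. Compound 1 `Fc1ccc(-c2nn3c(NC4CCCC4)cccc3c2-c2ccsc2)cc1` carries no result in an ADME assay on Vero cells (Chlorocebus sabaeus) for cytotoxicity; a lower number here means that less compound is tolerated, a higher number that more compound is tolerated: compound 1 gives "not determined" (no result reported). For the measured compounds named here, compound 2 `Fc1ccc(-c2nn3c(NC4CCCC4)cccc3c2-c2cc[nH]n2)cc1` is the one member with a single number: in this assay compound 2 gives 14000 nM. Compound 3 `Fc1ccc(-c2nn3c(NC4CCCC4)cccc3c2-c2ccnc(NC3CCCC3)c2)cc1` reaches only a limit of this assay, not a number: in this assay compound 3 gives > 40000 nM, which is the limit of > 40000 nM in this assay, at which 1 of the 3 values shown sits. Going by the values given here, of the three entries, compound 2 therefore holds the only plain number, with one further entry a limit and one without any result.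

Compound 4 `Nc1n[nH]cc1-c1c(-c2ccc(F)cc2)nn2c(NC3CCCC3)cccc12` is not yet measured. Against compound 2 it differs in a single place: 3-amino-1H-pyrazol-4-yl in place of 1H-pyrazol-3-yl on an aromatic carbon. Among the compounds with values here, no step between measured compounds that differ in one place exists in this set, so nothing shows how such a change moves this assay. In this assay the step of a 1.1-fold higher number from compound 2 to compound 4 (0.03 log units; within the scatter) is expected to lie within the scatter, in no particular direction. For compound 4 the estimate in this assay is 15000 nM, between 5000 nM and 40000 nM.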

Compound 4, half-maximal cytotoxic concentration: 20000 nM
For compound 4 the middle estimate is 1.3-fold (0.12 log units) below the measured one; low and high end bracket the measured number.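

This position, on an aromatic carbon of the core, now has its first readable step: in this assay, 3-amino-1H-pyrazol-4-yl in place of 1H-pyrazol-3-yl gives a 1.4-fold higher number from compound 2 to compound 4 (0.15 log units; within the scatter). The two pyrazoles therefore cannot be told apart in this read-out, and the additional hydrogen-bond donor and acceptor counted for the entering group come with no readable difference. No measurement shown gives a cause for this step.

On these data alone, it remains open whether the amino group and the different pyrazole attachment would each read the same on their own, and how a carboxylic acid or a morpholine ring would read at this position. Steps involving compound 1 and compound 3 cannot be read: compound 1 has no result and compound 3 gives only a limit, > 40000 nM.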